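From a 3-Chlorophenyl to a 2-Methoxyphenyl Group

The source may hold more compounds than are shown below. What is called first, only, known or untested is meant among the compounds shown, and "the series" means these compounds.

Compound 2 `S=c1oc(-c2ccc3c(c2)OCCO3)nn1CN1CCN(c2cccc(Cl)c2)CC1` is the starting point. Going by the values given here, in a functional assay on HeLa cells (Homo sapiens) for antiproliferative activity, read by MTT assay, with a stated time of 48 h (a higher number here means a weaker inhibitor, a lower number a stronger inhibitor), compound 2 gives 47200 nM, the only definite number among the two values here. Compound 1 `Cc1ccc(N2CCN(Cn3nc(-c4ccc5c(c4)OCCO5)oc3=S)CC2)c(C)c1` gives > 50000 nM in this assay, which is a limit of the assay rather than a number, as noted by the limit of > 50000 nM in this assay, at which 1 of the 2 values shown sits. The step of an at least 1.0-fold lower number from compound 1 to compound 2 (0.02 log units; that floor lies within the scatter) therefore shows at most a change that stays within the usual scatter. Compound 3 `COc1ccccc1N1CCN(Cn2nc(-c3ccc4c(c3)OCCO4)oc2=S)CC1` carries the change (2-methoxyphenyl in place of 3-chlorophenyl on an amine nitrogen in a ring). Among the compounds with values here, the one measured step that bears on this, from compound 1 to compound 2, also exchanged one substituted phenyl for another at the same ring nitrogen and moved the read-out hardly at all. For compound 3 no step beyond the scatter in this assay is therefore expected, and the step of a 1.1-fold higher number from compound 2 to compound 3 (0.03 log units; within the scatter) is estimated to be small. The value for compound 3 is expected near 50000 nM, within 20000 nM to 125000 nM.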

Compound 3, half-maximal inhibitory concentration: > 50000 nM
Compound 3 ended at the assay's limit; the forecaster's own chance of this, stated with the estimate: 55%; the middle value sits exactly at the limit.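

Putting 2-methoxyphenyl in place of 3-chlorophenyl on this ring nitrogen gives, in this assay, an at least 1.0-fold higher number from compound 2 to compound 3 (0.02 log units; that floor lies within the scatter), so adding an oxygen and a hydrogen-bond acceptor to this group produces no readable gain in activity. Compound 1 and compound 3 both carry a limit rather than a number, and the step between them cannot be read. With a third substituted phenyl group now tested at this nitrogen, the assay still gives no clear separation among these groups, and most of the results stop at the same limit: the limit of > 50000 nM in this assay, at which 2 of the 3 values shown sit.

The compounds shown leave open whether a benzyl group, a pyridine ring or a simple alkyl chain on this nitrogen would give a definite, clearly lower number. They also leave open whether an amine or a carboxylic acid on the phenyl ring would do so.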